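Working notes: from compound 3 to compound 4

This account rests on a few compounds, and the source may have more. Where it says the series, first, only, none or still open, it means among the compounds named here.

Of the compounds shown here, three on the shared core have been measured so far in an ADME assay on cells (Hepatocyte, Rattus norvegicus, strain Wistar) for pharmacokinetics, read by LC-MS, with a stated time of 90 min, tested at 1 uM (a lower number here means slower removal, a higher number faster removal of the compound), and are compared here. Compound 1 `COc1cc(C(=O)N2CC[C@@H](O)C(C)(C)C2)cc2nc(NCc3cccc(Cl)c3)oc12` gives 51.7 mL/min/kg in these measurements. Compound 2 `COc1cc(C(=O)N2CCC(O)C(C)C2)cc2nc(NCc3cccc(Cl)c3)oc12` gives 45 mL/min/kg in the same way. Compound 3 `COc1cc(C(=O)N2CC(C)C(O)CC2C)cc2nc(NCc3cccc(Cl)c3)oc12` gives 56.7 mL/min/kg and stands level with both others, since every step among the three lies within the scatter.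

Compound 4 `CCC1CC(O)C(C)CN1C(=O)c1cc(OC)c2oc(NCc3cccc(Cl)c3)nc2c1` carries one change from compound 3: methyl in place of hydrogen on a saturated chain carbon bound to a saturated ring carbon in all. This is methyl in place of hydrogen on a saturated chain carbon bound to a saturated ring carbon, which turns 4-hydroxy-2,5-dimethylpiperidin-1-yl into 2-ethyl-4-hydroxy-5-methylpiperidin-1-yl.

The closest evidence is a 1.3-fold higher number from compound 2 to compound 3 (0.10 log units; within the scatter) for methyl in place of hydrogen on a saturated ring carbon. Two further changes in the same substituent give a 1.1-fold lower number from compound 1 to compound 2 (0.06 log units; within the scatter) and a 1.1-fold higher number from compound 1 to compound 3 (0.04 log units; within the scatter) as their measured sizes. Among the measured compounds shown here, no measured compound carries the ethyl group, so the precedent is indirect. All three steps stay within the scatter, and nothing beyond it is expected here. The expected step is a 1.0-fold higher number from compound 3 to compound 4 (0.01 log units; within the scatter) and no larger than the scatter. For compound 4 the estimate is 58 mL/min/kg with an expected range from 38 mL/min/kg to 85 mL/min/kg on present evidence.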

Compound 4, clearance: 61.7 mL/min/kg
For compound 4 the middle estimate is 1.1-fold (0.03 log units) below the measured one; low and high end bracket the measured number.
By their numbers in this assay, from the lowest: compounds 2, 1, 3 and 4 (each within the scatter of the next).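

In this assay, among the compounds shown here, the methyl-to-ethyl change, with methyl in place of hydrogen on a saturated chain carbon bound to a saturated ring carbon, gives a 1.1-fold higher number from compound 3 to compound 4 (0.04 log units; within the scatter) and is the first measured change at this place on the shared core. The wider comparisons give a 1.4-fold higher number from compound 2 to compound 4 (0.14 log units; within the scatter) and a 1.2-fold higher number from compound 1 to compound 4 (0.08 log units; within the scatter), so none of the three steps to compound 4 leaves the scatter and the four compounds remain level in this read-out. Nothing at hand links this flat result to any measured property of the ethyl group or of the substituent as a whole.

The compounds shown leave open whether a longer chain, such as propyl or butyl, at this place would give a step beyond the scatter, or whether an amine or a carboxylic acid at the end of the chain would do so. On these data alone, all four compounds also keep the hydroxy group on the saturated ring, so the effect of a fluorine or a methoxy group in its place on the clearance remains unknown.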